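Benzoyl amide in a small amide series

The source may report more compounds than this note shows. Statements on the series, on what has been measured and on what is new or still open speak of the compounds shown alone.

Measured so far in a functional assay on U-87MG ATCC cells (Homo sapiens) for inhibition; on this read-out higher numbers stand for weaker inhibition and lower numbers for stronger inhibition
compound 1 `COc1cc(/C=C/C(=O)c2cccc(NC(=O)c3c(Cl)cccc3Cl)c2)ccc1O` gives 17.8 ug/mL
compound 2 `COc1cc(/C=C/C(=O)c2cccc(NC(=O)c3cccs3)c2)ccc1O` gives 14.7 ug/mL
compound 3 `COc1cc(/C=C/C(=O)c2cccc(NC(=O)c3ccc(Cl)cc3Cl)c2)ccc1O` gives > 50 ug/mL (a limit)

Compound 3 reads > 50 ug/mL as a limit of this assay and not a number. For the measured compounds named here, compound 4 `COc1cc(/C=C/C(=O)c2cccc(NC(=O)c3ccccc3)c2)ccc1O` has phenyl in place of 2,4-dichlorophenyl on a carbonyl carbon at the same place as all the measured steps. Two steps, an at least 2.8-fold higher number from compound 1 to compound 3 (0.44 log units; beyond the scatter) and an at least 3.4-fold higher number from compound 2 to compound 3 (0.53 log units; beyond the scatter) lie beyond the scatter, while a 1.2-fold lower number from compound 1 to compound 2 (0.08 log units; within the scatter) stays within it. Going by those two larger steps, a move towards lower numbers of like size is expected, with an at least 2.0-fold lower number from compound 3 to compound 4 (0.31 log units; beyond the scatter) as the estimated step. Compound 4 is estimated at 24 ug/mL in this assay on this basis, with 10 ug/mL to 55 ug/mL as the expected range.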

Compound 4, half-maximal inhibitory concentration: 8.82 ug/mL
Estimate against measurement, compound 4: 2.7-fold (0.43 log units) above; the measured number lies below the stated range.
By their numbers in this assay, from the lowest: compounds 4, 2 and 1 (each within the scatter of the next). At a limit, above all of these: compound 3.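

In this assay, a plain phenyl on the carbonyl carbon gives an at least 5.6-fold lower number from compound 3 to compound 4 (0.75 log units; beyond the scatter), so the loss in compound 3 goes with its 2,4-dichlorophenyl and not with an aromatic ring at this place as such. Phenyl stays within the scatter of the other two groups, with a 1.7-fold lower number from compound 2 to compound 4 (0.22 log units; within the scatter) and a 2.0-fold lower number from compound 1 to compound 4 (0.30 log units; within the scatter), so only compound 3 stands apart in this series. Compound 3 is a limit and not a number, so the size of its step stays unfixed: the limit of > 50 ug/mL in this assay, at which 1 of the 4 values shown sits.

From the compounds shown here alone, whether a monochlorophenyl, a cyclohexyl or a pyridyl group on the carbonyl carbon reads with compound 4 or with compound 3 stays open.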